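This account rests on a few compounds, and the source may have more. Where it says the series, first, only, none or still open, it means among the compounds named here.

Measured compounds in this series:
- compound 1, `COc1ccc(NCC(=O)Oc2ccc3c(C)cc(=O)oc3c2)cc1`: 37.2%
- compound 2, `Cc1cc(=O)oc2cc(OC(=O)CNc3ccc(Cl)cc3)ccc12`: 15.9%

In a functional assay on the whole organism (strain Wistar albino) for inhibition, with Rattus norvegicus as the target, read by paw edema, with stated times of 30 min and 3 h, at a dose of 20 mg/kg by the oral route (on this read-out higher numbers stand for more inhibition at the one dose given (going by the name of the read-out) and lower numbers for less inhibition), compound 2 gives 15.9% and stands lowest of the two numbers; its nearest neighbour is compound 1, which in this assay gives 37.2%. For the measured compounds named here, the one step between them, a number 21.3 percentage points lower from compound 1 to compound 2 (beyond the scatter), is the only step in hand.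

Compound 3, `Cc1cc(=O)oc2cc(OC(=O)CNc3ccc([N+](=O)[O-])cc3)ccc12`, is not yet measured. It differs from compound 2 as follows: nitro in place of chloro on an aromatic carbon. Going by the values given here, the only measured step that bears on this change is a number 21.3 percentage points lower from compound 1 to compound 2 (beyond the scatter), which also exchanges the substituent at the same position of the aniline ring; it shows that this position is sensitive, since the exchange of methoxy for chloro moved the number beyond the scatter. Among the compounds with values here, no step with a nitro group exists, so the direction for compound 3 cannot be read from a precedent. The step for compound 3 is therefore estimated as a number 9.1 percentage points higher from compound 2 to compound 3 (within the scatter), a small move with wide uncertainty. Compound 3 is expected to give about 25% in this assay, within the range 8% to 45%.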

Compound 3, a percentage reported as inhibition, in the whole organism at one dose (the size of the read-out at that dose, not a potency): 20.2%
Beside the measured number, compound 3's estimate is 4.8 percentage points above it; the measured number falls inside the stated range.
By their numbers in this assay, from the lowest: compounds 2 and 3 (each within the scatter of the next); then compound 1.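

In this assay, nitro in place of chloro on an aromatic carbon, para to a large group, gives a number 4.3 percentage points higher from compound 2 to compound 3 (within the scatter), so these two groups cannot be told apart at this position, although nitro brings more heavy atoms and two hydrogen-bond acceptors that chloro lacks. Methoxy now stands apart from nitro as well as from chloro, with a number 17 percentage points lower from compound 1 to compound 3 (beyond the scatter); the earlier pair alone could not show whether its gap was tied to methoxy or to chloro, whereas across these three compounds compound 1 is the one that differs from the other two. No measured property in hand accounts for this grouping.

The compounds shown leave open whether the higher number in this assay belongs to methoxy alone or would also appear with a hydroxyl group, an ethoxy group or an amine at this position. Also open, as far as these compounds go, is whether the same grouping of substituents would hold with a longer chain in place of the link from the aniline nitrogen to the shared core.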